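The source may report more compounds than this note shows. Statements on the series, on what has been measured and on what is new or still open speak of the compounds shown alone.

Measured so far:
compound 1, `Cc1c(OCCCCOc2cncc(C(=O)O)c2)ccc(C(=O)CC(C)(C)C)c1O`, 180 nM
compound 2, `Cc1ccc(C(=O)O)cc1OCCCCOc1ccc(C(=O)CC(C)(C)C)c(O)c1C`, 892 nM

Both numbers come from an assay for positive allosteric modulation of metabotropic glutamate receptor 3 (Rattus norvegicus); on this read-out higher numbers stand for an effect only at larger amounts of compound and lower numbers for an effect already at smaller amounts. Going by the values given here, on this read-out compound 2 stands highest of the two, with compound 1 as its only neighbour, and the one measured step, a 5.0-fold higher number from compound 1 to compound 2 (0.70 log units; beyond the scatter), shows that exchanging the acid-bearing aromatic group on the ether oxygen shifts the number by a modest amount.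

Compound 3, `Cc1c(OCCCCOc2ccc(C(=O)O)c(F)c2)ccc(C(=O)CC(C)(C)C)c1O`, has not yet been measured. It keeps the shared core of compound 2 and differs from it in one place: 4-carboxy-3-fluorophenyl in place of 5-carboxy-2-methylphenyl on an oxygen on a saturated carbon. Among the compounds with values here, the only measured step that bears on this change is the one from compound 1 to compound 2, where a different acid-bearing ring on the same oxygen moved the number modestly. That step gives the scale, but not the direction, for a further swap of the same kind, so for compound 3 a step of modest size is expected in this assay, most likely towards a lower number, though a change within the scatter cannot be ruled out. The expected step is a 1.8-fold lower number from compound 2 to compound 3 (0.25 log units; within the scatter). For compound 3 the estimate is 500 nM, with a range from 120 nM to 2000 nM.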

Compound 3, half-maximal effective concentration: 1110 nM
Compound 3: the middle estimate sits 2.2-fold (0.35 log units) below what was measured; the range from low to high includes it.
By their numbers in this assay, from the lowest: compound 1; then compounds 2 and 3 (each within the scatter of the next).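

In this assay, replacing 5-carboxy-2-methylphenyl with 4-carboxy-3-fluorophenyl on the oxygen gives a 1.2-fold higher number from compound 2 to compound 3 (0.09 log units; within the scatter), so these two acid-bearing rings of carbon only cannot be told apart on this read-out, even though they differ in both their substituent and the place of the acid. The ring of compound 1 now stands apart from two different carbon-only rings rather than one: alongside a 5.0-fold higher number from compound 1 to compound 2 (0.70 log units; beyond the scatter) there is now a 6.2-fold higher number from compound 1 to compound 3 (0.79 log units; beyond the scatter), and neither of compounds 2 and 3 goes against this pattern among the three compounds shown. Nothing available here explains why 5-carboxypyridin-3-yl differs from the other two rings.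

These compounds leave open whether the ring nitrogen of compound 1 accounts for the gap, as the carbon-only rings also differ from it in their substituents and in where the acid sits. From the compounds shown here alone, it also remains open how this assay would respond to a tetrazole in place of the carboxylic acid, or to a longer chain between the two ether oxygens.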